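A few compounds are considered here, and "the series" means these few. Any claim that something is new, unique, unknown or untested is made for them only; others in the source may bear on it.

Measured compounds:
compound 1 `O=C(CSc1nnnn1-c1ccccc1)N/N=c1/scc(-c2ccc(Cl)cc2)n1-c1ccccc1`, 69.3%
compound 2 `Cn1cnnc1SCC(=O)N/N=c1/scc(-c2ccc(C#N)cc2)n1-c1ccccc1`, 62.6%
compound 3 `O=C(CSc1nnnn1-c1ccccc1)N/N=c1/scc(-c2ccccc2)n1-c1ccccc1`, 47.1%

In a functional assay on C6 cells (Rattus norvegicus) for cytotoxicity, read by MTT assay, with a stated time of 24 h, tested at 12 ug/mL (a lower number here means a stronger effect, a higher number a weaker effect of the compound at the concentration tested), compound 3 gives the lowest of the three numbers. Its nearest neighbour is compound 2, which gives 62.6%, and the furthest is compound 1, which gives 69.3%, both gaps beyond the scatter.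

Compound 4 `N#Cc1ccc(-c2cs/c(=N/NC(=O)CSc3nnnn3-c3ccccc3)n2-c2ccccc2)cc1` is not yet measured. It differs from compound 3 by cyano in place of hydrogen on an aromatic carbon.

Going by the values given here, one measured step bears on this position: a number 22.2 percentage points lower from compound 1 to compound 3 (beyond the scatter), so taking a group off this aromatic carbon lowered the number by a modest amount beyond the scatter. Compound 2 carries the same cyano group at the same place on a different side chain and gives 62.6%, a number above that of compound 3. Putting a group back on this carbon is therefore expected to move the number upward in this assay, by an amount comparable in size to the step already described, a number 13.9 percentage points higher from compound 3 to compound 4 (beyond the scatter).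

Compound 4 is estimated at 61%, with a range from 48% to 74%.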

Compound 4, a percentage reported as activity, at one concentration (the size of the read-out at that concentration, not a potency): 74.1%
For compound 4 the middle estimate is 13.1 percentage points below the measured one; measured number outside the range, above it.
By their numbers in this assay, from the lowest: compound 3; then compounds 2, 1 and 4 (each within the scatter of the next, the first and the last beyond it).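

In this assay, the change from phenyl to 4-cyanophenyl gives a direct reading at this position (a number 27 percentage points higher from compound 3 to compound 4 (beyond the scatter)), and hydrogen now has a higher number on replacement by either chloro or cyano on this aromatic carbon. Cyano and chloro are not separated here (a number 4.8 percentage points higher from compound 1 to compound 4 (within the scatter)), so the two groups read alike on the shared core and side chain. The side chain also matters with cyano held in place, with 1-phenyl-1H-tetrazol-5-yl in place of 4-methyl-4H-1,2,4-triazol-3-yl on the sulfur (a number 11.5 percentage points higher from compound 2 to compound 4 (beyond the scatter)). No measurement bears on the reason for these steps.

On these data alone, whether a methoxy group or an amine on this carbon would read like chloro and cyano remains open. Also open, as far as these compounds go, is whether the step from hydrogen to cyano keeps its size on the 4-methyl-4H-1,2,4-triazol-3-yl side chain.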